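This account rests on a few compounds, and the source may have more. Where it says the series, first, only, none or still open, it means among the compounds named here.

Compound 1, `CC(=O)Nc1ccc(-c2nc3cc(C(F)(F)F)ccc3[nH]2)cc1` — in an ADME assay on MDBK cells (Bos taurus) for cytotoxicity, read by MTT assay, with a stated time of 96 h (a lower number here means that less compound is tolerated, a higher number that more compound is tolerated), compound 1 gives 50000 nM.
Compound 2, `O=[N+]([O-])c1ccc(-c2nc3cc(C(F)(F)F)ccc3[nH]2)cc1` — in this assay compound 2 gives 6000 nM.
Compound 3, `COc1ccc(-c2nc3cc(C(F)(F)F)ccc3[nH]2)c(OC)c1` — in this assay compound 3 gives > 100000 nM, which is a limit of the assay and not a number.

All three share the same core and differ only in the groups on the pendant six-membered ring. Compound 3 stands at the high end of what has been seen: its result is a limit, (the limit of > 100000 nM in this assay, at which 1 of the 3 values shown sits), so the true value is not pinned down, and compound 4 starts from that limit. Compound 4, `COc1ccc(-c2nc3cc(C(F)(F)F)ccc3[nH]2)cc1`, differs from compound 3 by a single change: hydrogen in place of methoxy on an aromatic carbon. Among the compounds with values here, the one measured step, an 8.3-fold lower number from compound 1 to compound 2 (0.92 log units; beyond the scatter), swaps one group for another rather than removing one, so it does not speak directly to this change. With nothing pointing one way or the other, no step beyond the scatter is expected in this assay, and the result may again be a limit. Compound 4 is therefore estimated at about 100000 nM, with a range from 40000 nM to 250000 nM. The expected step is a number no higher from compound 3 to compound 4 (the limit leaves the size open).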

Compound 4, half-maximal cytotoxic concentration: > 100000 nM
Compound 4 ended at the assay's limit (the forecaster's own chance of this, stated with the estimate: 50%); the middle value sits exactly at the limit.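

Taking the methoxy group away from compound 3 leaves compound 4 at the same limit in this assay, so the step between them cannot be read, and the removed group is not needed to stay at this limit: the limit of > 100000 nM in this assay, at which 2 of the 4 values shown sit.

The methoxy group that remains also allows a direct comparison at the position held by nitro and acetamido. Methoxy in place of nitro gives an at least 16-fold higher number from compound 2 to compound 4 (1.22 log units; beyond the scatter), a clear separation, whereas methoxy in place of acetamido gives an at least 2.0-fold higher number from compound 1 to compound 4 (0.30 log units; that floor lies within the scatter), whose floor does not by itself separate the two compounds.

From the compounds shown here alone, how far the true values of compound 3 and compound 4 lie past the limit stays open. So does whether an amine or a carboxylic acid in place of that methoxy group would lower the number, as nitro does in compound 2.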